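Swapping Bromo for Iodo: One Halogen Step

A few compounds are considered here, and "the series" means these few. Any claim that something is new, unique, unknown or untested is made for them only; others in the source may bear on it.

Compound 2, `C[C@@H](NC(=O)Nc1cccc(Br)c1)c1ccccc1`, gives 100% in an ADME assay on the whole organism with Oryza sativa as the target, tested at 0.1 uM; on this read-out lower numbers stand for a stronger effect and higher numbers for a weaker effect at the one concentration tested. Going by the values given here, of the two numbers measured so far, this is the highest; the nearest is compound 1, `C[C@@H](NC(=O)Nc1cccc(C(F)(F)F)c1)c1ccccc1`, which in this assay gives 82%. Among the compounds with values here, the only step measured between these two, a number 18 percentage points higher from compound 1 to compound 2 (beyond the scatter), lies beyond the scatter of repeated runs.

Compound 3, `C[C@@H](NC(=O)Nc1cccc(I)c1)c1ccccc1`, has not yet been measured. It differs from compound 2 in a single place: iodo in place of bromo on an aromatic carbon. Within the data shown here, the one measured step, a number 18 percentage points higher from compound 1 to compound 2 (beyond the scatter), concerns a different exchange, bromo for trifluoromethyl, so it tells little about replacing bromo with iodo. Among the measured compounds shown here, no measured step covers this exchange, and the expectation therefore rests on the value of compound 2 alone.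

Compound 3 is expected to give about 94% in this assay, in a range from 78% to 100%. The step this estimate implies, a number 6 percentage points lower from compound 2 to compound 3 (within the scatter), is expected to stay within the scatter, with the measured number for compound 3 still to come.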

Compound 3, a percentage reported as activity, at one concentration (the size of the read-out at that concentration, not a potency): 81%
Estimate against measurement, compound 3: 13 percentage points above, and the stated range covers the measured number.
By their numbers in this assay, from the lowest: compounds 3 and 1 (each within the scatter of the next); then compound 2.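

In this assay the exchange of bromo for iodo gives a number 19 percentage points lower from compound 2 to compound 3 (beyond the scatter) and shows that these two groups, though they are neighbours among the halogens, are not interchangeable at this place on the aromatic ring. Iodo and trifluoromethyl, by contrast, cannot be told apart here, with a number 1 percentage points lower from compound 1 to compound 3 (within the scatter) as the step between them, so among the three groups only the bromo of compound 2 stands apart. Nothing available explains why bromo differs from the other two groups.

Left open is where chloro, a methoxy group or an amine would fall at this place, and whether each would join compound 2 or sit with compound 1 and compound 3. Also open, from the compounds shown here alone, is whether the gap around bromo would hold with these groups elsewhere on the ring or at other concentrations, as each number here gives the size of the read-out at one concentration and is not a potency.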